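The source may report more compounds than this note shows. Statements on the series, on what has been measured and on what is new or still open speak of the compounds shown alone.

Compound 1 `O=C(NS(=O)(=O)c1ccc(F)cc1)c1ccncc1` is the starting point. In a functional assay on B16-F10 cells (Mus musculus) for antiproliferative activity, read by colorimetric assay and MTT assay, with a stated time of 48 h (a higher number here means a weaker inhibitor, a lower number a stronger inhibitor), compound 1 gives 13800 nM. Compound 2 `O=C(NS(=O)(=O)c1ccc(Br)cc1)c1ccncc1` differs from it in one place: bromo in place of fluoro on an aromatic carbon. In this assay compound 2 gives 8800 nM, and the step is a 1.6-fold lower number from compound 1 to compound 2 (0.20 log units; within the scatter). Compound 3 `O=C(NS(=O)(=O)c1ccc(F)cc1)c1ccccn1` keeps the halogen of compound 1 but carries a different core, and the two cores differ as follows: pyridin-2-yl in place of pyridin-4-yl on a carbonyl carbon. In this assay compound 3 gives 10900 nM, a step of a 1.3-fold lower number from compound 1 to compound 3 (0.10 log units; within the scatter).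

Compound 4 `O=C(NS(=O)(=O)c1ccc(Br)cc1)c1ccccn1` has not yet been measured. It differs from compound 3 in one place: bromo in place of fluoro on an aromatic carbon. This is the same change already seen from compound 1 to compound 2, and it occurs twice among these compounds, with the same surroundings in both cases. Beside the earlier step of a 1.6-fold lower number from compound 1 to compound 2 (0.20 log units; within the scatter), the step from compound 3 to compound 4 is expected to be a 1.6-fold lower number from compound 3 to compound 4 (0.19 log units; within the scatter), resting on that single earlier case. Compound 4 is therefore estimated at 7000 nM, with a range from 3500 nM to 14000 nM.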

Compound 4, half-maximal inhibitory concentration: 8500 nM
Compound 4: the middle estimate sits 1.2-fold (0.08 log units) below what was measured; the measured number falls inside the stated range.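

In this assay, bromo in place of fluoro gives a 1.3-fold lower number from compound 3 to compound 4 (0.11 log units; within the scatter), and beside its earlier case this change carries from one core to the other with no difference that can be told apart: the same change on two cores in this assay, a 1.6-fold lower number (0.20 log units; within the scatter) from compound 1 to compound 2 and a 1.3-fold lower number (0.11 log units; within the scatter) from compound 3 to compound 4, 1.2-fold (0.09 log units) apart, within the scatter of two such steps. Pyridin-2-yl in place of pyridin-4-yl gives a 1.0-fold lower number from compound 2 to compound 4 (0.02 log units; within the scatter), and this change likewise reads the same with either halogen: the same change on two cores in this assay, a 1.3-fold lower number (0.10 log units; within the scatter) from compound 1 to compound 3 and a 1.0-fold lower number (0.02 log units; within the scatter) from compound 2 to compound 4, 1.2-fold (0.09 log units) apart, within the scatter of two such steps. Within the data shown here, all of these steps lie within the scatter, so the agreement shows only that neither change moved the number measurably in these four compounds; it does not show that either change has a real effect, or that the same result would hold on any other core.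

Fluoro and bromo are the only groups shown at that place on the aromatic ring, so an amine, a methoxy group or a carboxylic acid there remains an open case. Going by these compounds, it also remains open what a longer chain on the carbonyl carbon, in place of the pyridine ring, would do.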